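Chain-end variation at the aryl ether of an allyl acetophenone core

A few compounds are considered here, and "the series" means these few. Any claim that something is new, unique, unknown or untested is made for them only; others in the source may bear on it.

Measured compounds:
compound 1 `C=CCc1cc(C(C)=O)c(O)cc1OCCCC#N` gives 47%; compound 2 `C=CCc1cc(C(C)=O)c(O)cc1OCCCCCC#N` gives 81%; compound 3 `C=CCc1cc(C(C)=O)c(O)cc1OCCCCCCC` gives 31%.

In an assay on isolated protein for inhibition of leukotriene B4 receptor 1 (Homo sapiens), tested at 10 uM (on this read-out lower numbers stand for less inhibition and higher numbers for more inhibition at the one concentration tested (going by the name of the read-out)), compound 3 stands lowest of the three; the nearest is compound 1 and the furthest compound 2. Compound 4 `C=CCc1cc(C(C)=O)c(O)cc1OCCCCCC(=O)N(C)C` differs from compound 3 by dimethylcarbamoyl in place of ethyl on a saturated chain carbon, five bonds along the chain from an oxygen on an aromatic ring. The step that bears on it most directly is a number 50 percentage points lower from compound 2 to compound 3 (beyond the scatter), at the same place on the chain; a number 16 percentage points lower from compound 1 to compound 3 (beyond the scatter) points the same way, and a number 34 percentage points higher from compound 1 to compound 2 (beyond the scatter) shows the chain-end group carrying a large effect. A rise beyond the scatter is therefore expected for compound 4, estimated as a number 34 percentage points higher from compound 3 to compound 4 (beyond the scatter). Compound 4 is expected to give 65% in this assay, within 40% to 85%.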

Compound 4, a percentage reported as inhibition, at one concentration (the size of the read-out at that concentration, not a potency): 92%
Compound 4: middle estimate off by 27 percentage points, on the low side; measured number above the stated range.
By their numbers in this assay, from the lowest: compound 3; then compound 1; then compound 2; then compound 4.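

In this assay, dimethylcarbamoyl in place of ethyl at the chain end gives a number 61 percentage points higher from compound 3 to compound 4 (beyond the scatter), so a nitrile is not the only chain end at this position that lifts the number over the ethyl end. Dimethylcarbamoyl in place of cyano at the same place still gives a number 11 percentage points higher from compound 2 to compound 4 (beyond the scatter), and against the shorter nitrile chain the step is a number 45 percentage points higher from compound 1 to compound 4 (beyond the scatter). Nothing at hand bears on the reason for these steps.

Open, as far as these compounds go, is how a carboxylic acid or a primary amide at this chain end would read. Also open, from the compounds shown here alone, is whether the dimethylcarbamoyl group holds its number on a shorter or longer chain.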